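The compounds below may be only part of what the source reports. "The series", "measured", "known", "first", "only" and "open" are said of these compounds alone.

Compound 1 `CN1CC(=O)N/C1=N\C(=O)Nc1ccccc1` gives 1360 nM.
Compound 2 `CN1CC(=O)N/C1=N\C(=O)Nc1ccc(Cl)cc1` gives the limit > 5000 nM.

Compound 1 is the only one of the two with a number in an assay on isolated protein for displacement of a labelled ligand from metabotropic glutamate receptor 5 (Homo sapiens); on this read-out lower numbers stand for stronger inhibition and higher numbers for weaker inhibition. Compound 2 stands at the limit of > 5000 nM in this assay, at which 1 of the 2 values shown sits. Compound 3 `CN1CC(=O)N/C1=N\C(=O)Nc1ccccc1Cl` differs from compound 1 by chloro in place of hydrogen on an aromatic carbon. Going by the values given here, the single measured step that bears on this, an at least 3.6-fold higher number from compound 1 to compound 2 (0.56 log units; beyond the scatter), likewise put chloro in place of hydrogen on an aromatic carbon of the same ring and moved the number upward. A step of similar character, toward weaker inhibition, is therefore expected here. Compound 3 is estimated at 3500 nM, with a range from 1500 nM to 8000 nM. That expected value implies a 2.6-fold higher number from compound 1 to compound 3 (0.41 log units; beyond the scatter).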

Compound 3, half-maximal inhibitory concentration: 2520 nM
Beside the measured number, compound 3's estimate is 1.4-fold (0.14 log units) above it, and the stated range covers the measured number.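

In this assay, chloro in place of hydrogen on an aromatic carbon ortho to a large group gives a 1.9-fold higher number from compound 1 to compound 3 (0.27 log units; within the scatter), so compound 3 cannot be told apart from compound 1. Chloro on this carbon therefore does not carry the clear step seen with chloro elsewhere on the same ring. Compound 2, that other chloro compound, stands at a limit of the assay: the limit of > 5000 nM in this assay, at which 1 of the 3 values shown sits.

On these data alone, whether an amine or a methoxy group on this same carbon would also stay within the scatter remains open. So does whether a larger halogen such as bromo would.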